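A few compounds are considered here, and "the series" means these few. Any claim that something is new, unique, unknown or untested is made for them only; others in the source may bear on it.

In a functional assay (spleen, spleen) for activation, with Mus musculus as the target (on this read-out lower numbers stand for an effect already at smaller amounts and higher numbers for an effect only at larger amounts of compound), three compounds have been measured so far. Compound 1 `Nc1ncnc2c1nc(O)n2C1CCCC1` gives only a limit of the assay, > 10 uM. Compound 3 `Nc1ncnc2c1nc(I)n2Cc1ccccc1` likewise gives only a limit, > 10 uM. Going by the values given here, compound 2 `CCSc1nc(N)c2nc(O)n(Cc3ccccc3)c2n1` gives 0.1 uM, the only real number among the three. Compounds 1 and 3 sit at the limit of > 10 uM in this assay, at which 2 of the 3 values shown sit. Compound 4 `Nc1nc(O)nc2c1nc(O)n2Cc1ccccc1` has not yet been measured; it differs from compound 2 by hydroxy in place of ethylsulfanyl on an aromatic carbon. No step between two measured compounds is known, so the size of this change in this assay cannot be read off the data shown. The expectation is a moderate loss, an estimated step of a 10-fold higher number from compound 2 to compound 4 (1.00 log units; beyond the scatter). Compound 4 is expected to give about 1 uM, within 0.1 uM to 10 uM.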

Compound 4, minimum effective concentration: 0.1 uM
Compound 4: middle estimate off by 10-fold (1.00 log units), on the high side, and the stated range covers the measured number.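

In this assay, the aromatic carbon between two ring nitrogen atoms accepts hydroxy in place of ethylsulfanyl, with no change at the digits printed from compound 2 to compound 4 (within the scatter). The ethylsulfanyl chain is therefore not required for an effect at this level, and a single oxygen carrying a hydrogen-bond donor can stand in its place. Neither compound 2 nor compound 4 sits at the limit reached by the other two compounds, which is a limit and not a number: the limit of > 10 uM in this assay, at which 2 of the 4 values shown sit.

From the compounds shown here alone, whether an amine, a methoxy group or a longer chain such as butylsulfanyl would hold the same level at this position remains open.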